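This account rests on a few compounds, and the source may have more. Where it says the series, first, only, none or still open, it means among the compounds named here.

Measured so far in an assay on a protein complex for inhibition of integrin alpha-5/beta-1 (Homo sapiens), read by ELISA; a higher number here means a weaker inhibitor, a lower number a stronger inhibitor:
- compound 1 `Cc1cc(C)c(S(=O)(=O)N[C@@H](CNC(=O)CO[C@@H]2C[C@@H](CNc3ccccn3)N(C(=O)CCc3ccccc3)C2)C(=O)O)c(C)c1` gives 25 nM
- compound 2 `COc1ccnc(NC[C@@H]2C[C@@H](OCC(=O)NC[C@H](NC(=O)c3c(C)cc(C)cc3C)C(=O)O)CN2C(=O)OCc2ccccc2)c1` gives 0.54 nM

Compound 1 has the higher number of the two. Compound 2 lies far lower, well beyond the scatter, but the two structures differ in several places at once, so the gap cannot be assigned to any single change.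

Compound 3 `Cc1cc(C)c(S(=O)(=O)N[C@@H](CNC(=O)CO[C@@H]2C[C@@H](CNc3ccccn3)N(C(=O)OCc3ccccc3)C2)C(=O)O)c(C)c1` is compound 1 with one change on the carbonyl carbon attached to the amide-type nitrogen in the ring: benzyloxy in place of phenethyl on a carbonyl carbon

Compound 2 carries the same benzyloxycarbonyl on its ring nitrogen and gives the lower number of the measured pair; that is the only pointer available, and it is entangled with the other differences between compound 1 and compound 2. On that basis the step is expected to lower the number by more than the scatter, yet to stop short of the full distance to compound 2; the estimated step is a 3.1-fold lower number from compound 1 to compound 3 (0.49 log units; beyond the scatter). Compound 3 is expected to give 8 nM in this assay, with the estimate ranging from 2 nM to 30 nM.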

Compound 3, half-maximal inhibitory concentration: 3.7 nM
Compound 3: the middle estimate sits 2.2-fold (0.33 log units) above what was measured; low and high end bracket the measured number.
By their numbers in this assay, from the lowest: compound 2; then compound 3; then compound 1.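

In this assay, within the data shown here, benzyloxy in place of phenethyl on a carbonyl carbon gives a 6.8-fold lower number from compound 1 to compound 3 (0.83 log units; beyond the scatter), the first reading of this position with the rest of the core of compound 1 held fixed. The two groups match in heavy-atom count and each carries one six-membered aromatic ring of carbon only, but benzyloxy brings an oxygen and a hydrogen-bond acceptor that phenethyl lacks, so the number in this position moves with a change that leaves the group's size by count the same. No measured evidence is available to explain the step, so it stands as an observation only.

Compound 2 differs from compound 3 in more than one place, so the remaining gap to compound 2 cannot be assigned to any single part of the structure. Also open, going by these compounds, is how this carbonyl position would respond to other groups on the same carbon, such as a benzylamino group, which would set a nitrogen where benzyloxy has its oxygen, or a longer chain such as phenylpropyl.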